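A few compounds are considered here, and "the series" means these few. Any claim that something is new, unique, unknown or untested is made for them only; others in the source may bear on it.

Compound 1 `Nc1ccc(Nc2c(C(=O)NCc3ccc(F)cc3)nc(Br)c3cccnc23)cc1`: 7000 nM
Compound 2 `O=C(NCCCNc1c(C(=O)NCc2ccc(F)cc2)nc(Br)c2cccnc12)c1ccccc1`: > 20000 nM
Compound 3 `CNc1c(C(=O)NCc2ccc(F)cc2)nc(Br)c2cccnc12`: > 20000 nM
Compound 4 `COC(=O)CNc1c(C(=O)NCc2ccc(F)cc2)nc(Br)c2cccnc12`: not yet measured

All of these values come from a functional assay on MDA-MB-435 cells (Homo sapiens) for cytotoxicity, read by MTT assay, with a stated time of 72 h; on this read-out lower numbers stand for stronger inhibition and higher numbers for weaker inhibition. Compound 3 stands at > 20000 nM, which is a limit of the assay and not a number. Compound 2 also reads > 20000 nM, again a limit. Most of the series therefore sits at the limit of > 20000 nM in this assay, at which 2 of the 3 values shown sit. Only compound 1 gives an actual number.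

Compound 4 differs from compound 3 by one change, methoxycarbonyl in place of hydrogen on a saturated chain carbon bound to a nitrogen on an aromatic ring. This turns methyl into (methoxycarbonyl)methyl.

For the measured compounds named here, two measured steps concern the group on that nitrogen. The readable one is an at least 2.8-fold higher number from compound 1 to compound 3 (0.45 log units; beyond the scatter), and it removes the 4-aminophenyl group. The other, a step that the two limits leave unreadable from compound 2 to compound 3, cannot be sized. Neither step involves methoxycarbonyl, so no clear step is expected, and another reading at the limit is the likeliest outcome.

The expected change is a number no higher from compound 3 to compound 4 (the limit leaves the size open). Compound 4 is estimated at about 20000 nM, with an expected range of 9000 nM to 40000 nM.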

Compound 4, half-maximal inhibitory concentration: 10000 nM
Beside the measured number, compound 4's estimate is 2.0-fold (0.30 log units) above it; the measured number falls inside the stated range.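

Methoxycarbonyl on this chain carbon gives an at least 2.0-fold lower number from compound 3 to compound 4 (0.30 log units; that floor lies within the scatter), and putting it in place of 2-benzamidoethyl gives an at least 2.0-fold lower number from compound 2 to compound 4 (0.30 log units; that floor lies within the scatter), so the change may be real, but neither floor clears the usual scatter on its own. For the compounds shown here, what is new is that 4-aminophenyl is no longer the only group on this nitrogen to give an actual number in this assay, and (methoxycarbonyl)methyl stands level with it, with a 1.4-fold higher number from compound 1 to compound 4 (0.15 log units; within the scatter). Compound 2 and compound 3 still give a limit and not a number: the limit of > 20000 nM in this assay, at which 2 of the 4 values shown sit.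

On these data alone, the full size of the gain from methyl remains unknown, and the step between compound 2 and compound 3 cannot be read. As far as these compounds go, it is also open whether a carboxylic acid or a primary amide in place of the methyl ester, or a longer chain carrying that ester, would give a lower number.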